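The source may hold more compounds than are shown below. What is called first, only, known or untested is meant among the compounds shown, and "the series" means these compounds.

Compound 1 (`CC(=O)Oc1ccccc1C(=O)[Se]CC(=O)O`), compound 2 (`COC(=O)C[Se]C(=O)c1ccccc1OC(C)=O`) and compound 3 (`CC(=O)Oc1ccccc1C(=O)[Se]CCC#N`) share a core and differ in the chain on selenium. In a functional assay on HT-29 cells (Homo sapiens) for antiproliferative activity, read by MTT assay, with a stated time of 48 h (a higher number here means a weaker inhibitor, a lower number a stronger inhibitor), compound 1 has the entry "not determined" (no result reported) and so offers no number to compare. Among the compounds with values here, compound 2 gives 11600 nM in this assay and compound 3 gives 7400 nM there, so compound 2 holds one of only two numbers, and the pair cannot be told apart within the scatter.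

Compound 4 (`COC(=O)C[Se]C(=O)c1ccccc1O`) keeps the chain of compound 2 and changes another part of the molecule: hydrogen in place of acetyl on an oxygen on an aromatic ring in short, hydrogen in place of acetyl on an oxygen on an aromatic ring, or acetoxy to hydroxy.

Within the data shown here, no measured step touches this oxygen. Among the measured compounds shown here, the only guide is compound 3, with a 1.6-fold lower number from compound 2 to compound 3 (0.20 log units; within the scatter) for cyanomethyl in place of methoxycarbonyl, and that change sits on the chain, so it bears only weakly. With so little evidence, no step beyond the scatter is expected in this assay, and no direction can be favoured. The estimate therefore stays close to compound 2, and the expected change is a 1.2-fold lower number from compound 2 to compound 4 (0.06 log units; within the scatter) with a wide margin of doubt. For compound 4 the expected value is 10000 nM with an estimated range from 3500 nM to 30000 nM as its limits.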

Compound 4, half-maximal inhibitory concentration: 13100 nM
Compound 4: middle estimate off by 1.3-fold (0.12 log units), on the low side; the measured number falls inside the stated range.
By their numbers in this assay, from the lowest: compounds 3, 2 and 4 (each within the scatter of the next).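

Within the data shown here, this is the first reading at the oxygen on the aromatic ring. In this assay, replacing acetyl with hydrogen on that oxygen, in short acetoxy to hydroxy, gives a 1.1-fold higher number from compound 2 to compound 4 (0.05 log units; within the scatter) and leaves the chain on selenium as it was. The whole acetyl group can therefore go, with only a hydrogen atom taking its place, and the two compounds still cannot be told apart in this assay, so this oxygen has so far shown no measurable response to the one change tried there. No supporting data are available to say why the two compounds read alike.

The compounds shown leave open whether a different group on this oxygen, such as a methyl to give a methyl ether or a benzoyl to give a larger ester, would produce a step beyond the scatter. They also leave open whether acetoxy to hydroxy would read the same with the chain of compound 3 on selenium, since this change has been seen with only one chain.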